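Moving the amine on the arylidene ring of a thiazolidinedione

The source may report more compounds than this note shows. Statements on the series, on what has been measured and on what is new or still open speak of the compounds shown alone.

Measured compounds:
Compound 1, `Nc1ccc(/C=C2\SC(=O)N(Cc3ccc(C(F)(F)F)cc3)C2=O)cc1`: 32000 nM
Compound 2, `Nc1ccc(/C=C2\SC(=O)N(Cc3cccc(Cl)c3)C2=O)cc1`: 18000 nM
Compound 3, `Cc1ccc(CN2C(=O)S/C(=C\c3cccc(N)c3)C2=O)cc1`: > 250000 nM

In a functional assay on CCRF-CEM cells (Homo sapiens) for cytotoxicity, read by cell counting, with a stated time of 3 days (on this read-out lower numbers stand for stronger inhibition and higher numbers for weaker inhibition), compound 1 gives 32000 nM and compound 2 gives 18000 nM, and these two values lie within the usual scatter of each other. Within the data shown here, for compound 3 the assay reports only a limit, > 250000 nM; this is the limit described by the limit of > 250000 nM in this assay, at which 1 of the 3 values shown sits, and compound 3 is the one of the three that sits there, so no number is known for it and no measured step starts from it.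

Compound 4, `Cc1ccc(CN2C(=O)S/C(=C\c3ccc(N)cc3)C2=O)cc1`, has not yet been measured in this assay. It differs from compound 3 in one way: 4-aminophenyl in place of 3-aminophenyl on a double-bonded chain carbon bound to a double-bonded ring carbon. The 4-aminophenyl that enters is the group carried by compound 1 and compound 2, both of which return numbers rather than a limit, while the 4-methylbenzyl of compound 4 is shared with compound 3.

The step expected here runs from the limit of compound 3 toward a measurable value, and its size is given by an at least 6.2-fold lower number from compound 3 to compound 4 (0.79 log units; beyond the scatter), an estimate rather than a measured step. Compound 4 is expected to give 40000 nM, with a likely range from 12000 nM to 250000 nM.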

Compound 4, half-maximal inhibitory concentration: > 250000 nM
Compound 4: no number, only a limit; the forecaster's own chance of this, stated with the estimate: 25%; middle value at least 6.2-fold (0.79 log units) away from the limit.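

In this assay compound 4 gives only a limit, > 250000 nM. Compound 3 and compound 4 therefore share one limit of the assay, the step between them cannot be read, and 4-aminophenyl in place of 3-aminophenyl on a double-bonded chain carbon bound to a double-bonded ring carbon brings no number into view on the 4-methylbenzyl compounds: the limit of > 250000 nM in this assay, at which 2 of the 4 values shown sit. With 4-aminophenyl held fixed, the other substituent decides whether a number appears at all: 4-methylphenyl in place of 3-chlorophenyl on a saturated chain carbon bound to an amide-type nitrogen in a ring gives an at least 13-fold higher number from compound 2 to compound 4 (1.14 log units; beyond the scatter), and methyl in place of trifluoromethyl on an aromatic carbon gives an at least 7.8-fold higher number from compound 1 to compound 4 (0.89 log units; beyond the scatter).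

The compounds shown leave open whether 3-aminophenyl would return a number alongside 3-chlorobenzyl or 4-trifluoromethylbenzyl, the pairings in which the move of the amine could be read as a size. They also leave open how a hydroxyl or a carboxylic acid in place of the amine would behave.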